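The source may report more compounds than this note shows. Statements on the series, on what has been measured and on what is new or still open speak of the compounds shown alone.

Measured so far: compound 1 `O=[N+]([O-])C1=Cc2cccc(I)c2OC1C(F)(F)F`, which in an assay on 1321N1 cells for antagonist activity at P2Y purinoceptor 6 (Mus musculus), read by FLIPR and calcium flux (a higher number here means a weaker inhibitor, a lower number a stronger inhibitor), gives 17600 nM; and compound 2 `O=[N+]([O-])C1=Cc2cc(C#Cc3ccc(CO)cc3)ccc2OC1C(F)(F)F`, which in this assay gives 31600 nM.

For the measured compounds named here, compound 2 has the higher of the two numbers, but its only neighbour, compound 1, lies within the usual scatter of it, so the two compounds cannot be set apart. Compound 3 `CC[Si](C#Cc1ccc2c(c1)C=C([N+](=O)[O-])C(C(F)(F)F)O2)(CC)CC` differs from compound 2 by a group of 7 heavy atoms (6 carbon, 1 silicon; no ring) in place of a group of 8 heavy atoms (7 carbon, 1 oxygen; one six-membered aromatic ring of carbon only), on a triple-bonded carbon. From the compounds shown here alone, no comparable change has been measured, so the size of the step is unknown; the expectation is for no step beyond the scatter, in either direction, meaning a 1.3-fold lower number from compound 2 to compound 3 (0.10 log units; within the scatter). Compound 3 is therefore estimated at 25000 nM, with a range from 8000 nM to 80000 nM.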

Compound 3, half-maximal inhibitory concentration: 4940 nM
Beside the measured number, compound 3's estimate is 5.1-fold (0.70 log units) above it, outside the stated range (below it).
By their numbers in this assay, from the lowest: compound 3; then compounds 1 and 2 (each within the scatter of the next).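

On a triple-bonded carbon, a group with no ring and no hydrogen-bond donor or acceptor can take the place of 4-(hydroxymethyl)phenyl in this assay without loss, and the change gives a 6.4-fold lower number from compound 2 to compound 3 (0.81 log units; beyond the scatter) in the number. For the compounds shown here, this is the first step beyond the scatter, so the group at this position does affect the read-out. Nothing at hand accounts for the step.

From the compounds shown here alone, the ring, the hydroxymethyl group and the silicon all change at once, so which of them carries the step stays open. An unsubstituted phenyl or a tert-butyl group in the same place would separate them.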